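The compounds below may be only part of what the source reports. "The series", "measured", "known", "first", "only" and "open" are said of these compounds alone.

The measured compounds:
compound 1 `CC(C)(C)OC(=O)/C=C/NC(=O)[C@H](O)C(C)(C)CO` gives -1% in an ADME assay on HEK293 cells (Homo sapiens) for inhibition, read by CellTiter-Glo, with a stated time of 96 h, tested at 100 uM; on this read-out higher numbers stand for more inhibition at the one concentration tested (going by the name of the read-out) and lower numbers for less inhibition;
compound 2 `CCOC(=O)/C=C/NC(=O)[C@@H](O)C(C)(C)CO` gives -9% in this assay;
compound 3 `CC(C)(C)OC(=O)/C=C/NC(=O)[C@@H](O)C(C)(C)CO` gives -8% in this assay.

Among these three numbers compound 1 stands highest, yet none of the others lies apart from it. Its nearest neighbour is compound 3, with a number 7 percentage points lower from compound 1 to compound 3 (within the scatter), a change that turns only on (the fact that compounds 1 and 3 differ only in the configuration as drawn). The gap to compound 2, the furthest of the three, is likewise within the scatter, so the three compounds are in effect indistinguishable in this assay.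

The unmeasured compound 4 `CC(C)(CO)[C@@H](O)C(=O)N/C=C/C(=O)OCc1ccccc1` arises from compound 1 by benzyl in place of tert-butyl on an oxygen next to a carbonyl group. Among the compounds with values here, the one measured step that touches the same position is that from compound 2 to compound 3, where ethyl gave way to tert-butyl on that oxygen with a number 1 percentage points higher from compound 2 to compound 3 (within the scatter). Exchanging one group at this oxygen for another thus left the read-out unmoved, and the exchange of tert-butyl for benzyl is expected to behave the same way: a step of about a number 4 percentage points lower from compound 1 to compound 4 (within the scatter), that is, none beyond the scatter, is expected. Compound 4 is accordingly estimated at -5%, within a range from -15% to 8%.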

Compound 4, a percentage reported as inhibition, at one concentration (the size of the read-out at that concentration, not a potency): 5%
For compound 4 the middle estimate is 10 percentage points below the measured one, and the stated range covers the measured number.
By their numbers in this assay, from the lowest: compounds 2, 3, 1 and 4 (each within the scatter of the next, the first and the last beyond it).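

In this assay, benzyl in place of tert-butyl on an oxygen next to a carbonyl group gives a number 6 percentage points higher from compound 1 to compound 4 (within the scatter). Until now this oxygen had carried only ethyl and tert-butyl, so compound 4 adds a group with one six-membered aromatic ring of carbon only, and even this larger exchange produces no step beyond the scatter at this position. Nothing on record accounts for this flat response, and the only available fact concerns the configuration of two other compounds, not this exchange.

The compounds shown leave open how the read-out would respond at this position to a carboxylic acid in place of the ester, or to an amine carried on the group attached to this oxygen. They also leave open whether benzyl would behave the same way with the other configuration as drawn at the stereocentre that separates compound 1 from compound 3, and whether a change elsewhere in the shared core would produce a step beyond the scatter.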